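This account rests on a few compounds, and the source may have more. Where it says the series, first, only, none or still open, it means among the compounds named here.

In an ADME assay on KB-V1 cells (Homo sapiens) for cytotoxicity (a lower number here means a stronger inhibitor, a higher number a weaker inhibitor), compound 3 `COc1ccc(-n2cnnc2-c2cc(OC)c(OC)c(OC)c2)cc1O` gives 544 nM, within the scatter of both compound 1 `COc1ccc(-n2cnnc2-c2cc(OC)c(OC)c(OC)c2)cc1` at 907 nM and compound 2 `COc1cc(-c2nncn2-c2ccc(N(C)C)cc2)cc(OC)c1OC` at 323 nM. Compound 4 `COc1ccc(-n2cnnc2-c2cc(OC)c(OC)c(OC)c2)cc1F` has fluoro in place of hydroxy on an aromatic carbon, ortho to a methoxy group and meta to a large group: fluoro in place of hydroxy on an aromatic carbon. Among the compounds with values here, no fluoro compound has been measured yet. The closest evidence is a 1.7-fold lower number from compound 1 to compound 3 (0.22 log units; within the scatter), a step within the scatter at this same carbon. The other measured change, a 2.8-fold lower number from compound 1 to compound 2 (0.45 log units; beyond the scatter), goes beyond the scatter but concerns dimethylamino in place of methoxy, so it bears only weakly. No step beyond the scatter is therefore expected in this assay, with a slight lean towards a higher number. The expected change is a 1.2-fold higher number from compound 3 to compound 4 (0.08 log units; within the scatter). For compound 4 the estimate is 650 nM, with an expected range of 280 nM to 1500 nM.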

Compound 4, half-maximal inhibitory concentration: 1480 nM
For compound 4 the middle estimate is 2.3-fold (0.36 log units) below the measured one, within the range that was stated.
By their numbers in this assay, from the lowest: compounds 2, 3, 1 and 4 (each within the scatter of the next, the first and the last beyond it).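

In this assay, within the data shown here, this carbon responds to the group it carries: fluoro in place of hydroxy gives a 2.7-fold higher number from compound 3 to compound 4 (0.43 log units; beyond the scatter) as the first step beyond the scatter at this position. Fluoro in place of hydrogen gives a 1.6-fold higher number from compound 1 to compound 4 (0.21 log units; within the scatter) and stays within the scatter, so only hydroxy and fluoro separate clearly here, while hydrogen lies within the scatter of both. Nothing available accounts for the gap between hydroxy and fluoro. Open, on these data alone, is where chloro or a nitrile at this carbon would fall relative to hydroxy and fluoro.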